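The source may report more compounds than this note shows. Statements on the series, on what has been measured and on what is new or still open speak of the compounds shown alone.

Measured so far in a functional assay on the whole organism (strain Wister albino) for inhibition, with Rattus norvegicus as the target, read by paw edema, with stated times of 1 h and 4 h, at a dose of 50 mg/kg by the intraperitoneal route; a lower number here means less inhibition, a higher number more inhibition at the dose given (going by the name of the read-out):
compound 1, `CN1C[C@@H](c2ccccc2)[C@@]2(Cc3ccccc3C2=O)[C@@]12C(=O)Nc1ccccc12`, gives 39.3%
compound 2, `CN1C(=O)[C@@]2(c3ccccc31)N(C)C[C@@H](c1ccco1)[C@@]21Cc2ccccc2C1=O`, gives 8.2%
compound 3, `CN1C(=O)[C@@]2(c3ccccc31)N(C)C[C@@H](c1ccc(F)cc1)[C@@]21Cc2ccccc2C1=O`, gives 25.5%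

Compound 1 stands highest of these three numbers; compound 3 sits below it by a gap beyond the scatter, and compound 2 lower still. Compound 4, `CN1C[C@@H](c2cccs2)[C@@]2(Cc3ccccc3C2=O)[C@@]12C(=O)Nc1ccccc12`, differs from compound 1 in one place: thiophen-2-yl in place of phenyl on a saturated ring carbon. Among the measured compounds shown here, only one measured step concerns a change of the aromatic group on that saturated ring carbon: a number 17.3 percentage points higher from compound 2 to compound 3 (beyond the scatter), found on a core that differs from the core of compound 1. There a five-membered aromatic ring with one hetero atom gave the lower number and a six-membered ring of carbon only gave the higher one. For the measured compounds named here, the change to compound 4 runs the other way, from a six-membered ring of carbon only to a five-membered ring with one hetero atom, though with sulfur in place of oxygen, and no measured pair shows sulfur. A downward step of modest size is therefore expected, a number 10.3 percentage points lower from compound 1 to compound 4 (beyond the scatter). Compound 4 is estimated at 29%, within a range from 15% to 42%.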

Compound 4, a percentage reported as inhibition, in the whole organism at one dose (the size of the read-out at that dose, not a potency): 20%
Estimate against measurement, compound 4: 9 percentage points above, and the stated range covers the measured number.
By their numbers in this assay, from the lowest: compound 2; then compounds 4 and 3 (each within the scatter of the next); then compound 1.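

In this assay, among the compounds shown here, the first measured change of this group on the core of compound 1, thiophen-2-yl in place of phenyl on the saturated ring carbon, gives a number 19.3 percentage points lower from compound 1 to compound 4 (beyond the scatter). The earlier step, a number 17.3 percentage points higher from compound 2 to compound 3 (beyond the scatter), came from a different core and a different pair of groups, so the five-membered aromatic ring with one hetero atom now gives the lower number in both pairs, with sulfur in one and oxygen in the other. Nothing available explains why the number falls with this swap.

Still open, on these data alone, is how furan-2-yl or 4-fluorophenyl would compare with phenyl on the core of compound 1. Also open, as far as these compounds go, is where a pyridin-2-yl ring, a cyclohexyl ring or a phenyl ring carrying an amine would fall at this saturated ring carbon.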